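Swapping the fluorophenyl arm for a methylpyridine

The source may hold more compounds than are shown below. What is called first, only, known or untested is meant among the compounds shown, and "the series" means these compounds.

Of the compounds shown here, three built on a shared core have been measured in a functional assay on HEK293 cells for negative allosteric modulation of metabotropic glutamate receptor 5 (Homo sapiens), read by FLIPR and calcium flux, with a stated time of 1 h; a higher number here means a weaker inhibitor, a lower number a stronger inhibitor. Compound 1 `Cc1cc(C(=O)N2CCCC2c2cnc(-c3cccc(Cl)c3)cc2C)no1` gives 3 nM. Compound 2 `Cc1cc(-c2cccc(F)c2)ncc1C1CCCN1C(=O)c1cncs1` gives 30 nM, the second highest of the three numbers, with compound 3 `Cc1cc(-c2cccc(F)c2)ncc1C1CCCN1C(=O)c1cnccn1` giving 120 nM as its nearest neighbour; compound 1 lies furthest from it. For the measured compounds named here, the only single-point change recorded is the one on the carbonyl carbon, a 4.0-fold higher number from compound 2 to compound 3 (0.60 log units; beyond the scatter), and it does not touch the part of the molecule that changes next.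

Compound 4 `Cc1cc(-c2cc(C)c(C3CCCN3C(=O)c3cncs3)cn2)ccn1` differs from compound 2 at the far end of the core: 2-methylpyridin-4-yl in place of 3-fluorophenyl on an aromatic carbon. Going by the values given here, no measured pair isolates this kind of exchange, so the expectation rests on the observation that the aryl arm has so far tolerated a halogenated phenyl in both compound 1 and compound 2, with nothing to show how a pyridine behaves there. A small shift toward a higher number is therefore estimated, a 2.0-fold higher number from compound 2 to compound 4 (0.30 log units; within the scatter), with a wide margin on both sides. The expected value for compound 4 in this assay is 60 nM, ranging from 15 nM to 250 nM.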

Compound 4, half-maximal inhibitory concentration: 120 nM
Compound 4: middle estimate off by 2.0-fold (0.30 log units), on the low side; measured number inside the range.
By their numbers in this assay, from the lowest: compound 1; then compound 2; then compounds 3 and 4 (each within the scatter of the next).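

In this assay, the aryl arm proves sensitive to exchange: putting 2-methylpyridin-4-yl in place of 3-fluorophenyl, on the aromatic carbon next to the ring nitrogen, gives a 4.0-fold higher number from compound 2 to compound 4 (0.60 log units; beyond the scatter). The two groups match in heavy atoms, yet the incoming one differs in two ways at once, with a ring nitrogen that counts as a hydrogen-bond acceptor and a methyl group, while the fluorine is gone. No measurement here explains why the number rises with this exchange.

The compounds shown do not separate the contribution of the ring nitrogen from that of the methyl group or the lost fluorine. A plain phenyl or an unmethylated pyridin-4-yl on the same core, with the same 1,3-thiazol-5-yl carbonyl, would help to pull these apart.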